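The source may report more compounds than this note shows. Statements on the series, on what has been measured and on what is new or still open speak of the compounds shown alone.

Compounds measured so far:
Compound 1, `O=C(CN1CCN(c2nnc(Cc3ccncc3)c3ccccc23)CC1)Nc1ccc(F)c(Cl)c1`: 4 nM
Compound 2, `O=C(CN1CCN(c2nnc(Cc3ccccc3)c3ccccc23)CC1)Nc1ccc(F)c(F)c1`: 2750 nM
Compound 3, `O=C(CN1CCN(c2nnc(Cc3ccccc3)c3ccccc23)CC1)Nc1ccc(F)c(Cl)c1`: 7360 nM

In a functional assay on MDA-MB-231 cells (Homo sapiens) for cytotoxicity, read by MTT assay, with a stated time of 72 h (a higher number here means a weaker inhibitor, a lower number a stronger inhibitor), compound 1 stands lowest of the three numbers, that is, as the strongest inhibitor, with compound 2 the nearest and compound 3 the furthest, both far beyond the scatter. Two steps connect the measured compounds. The step of a 1800-fold higher number from compound 1 to compound 3 (3.26 log units; beyond the scatter) is large and concerns the group on the saturated chain carbon, which compound 4 keeps as it is in compound 1. The step of a 2.7-fold higher number from compound 2 to compound 3 (0.43 log units; beyond the scatter) is modest and concerns the ring on the amide-type nitrogen, the same region that compound 4 alters.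

Compound 4, `Cc1ccccc1NC(=O)CN1CCN(c2nnc(Cc3ccncc3)c3ccccc23)CC1`, is not yet measured. It differs from compound 1 in one place: 2-methylphenyl in place of 3-chloro-4-fluorophenyl on an amide-type nitrogen. Going by the values given here, no measured pair shows this exact exchange, only the modest halogen step on that ring. A change on that ring is therefore expected to matter less than the large step at the chain carbon, but removing both halogens goes further than anything measured, so some loss is expected. Compound 4 is expected to give 60 nM, within 6 nM to 900 nM, a step of a 15-fold higher number from compound 1 to compound 4 (1.18 log units; beyond the scatter) from compound 1.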

Compound 4, half-maximal inhibitory concentration: 200 nM
The estimate for compound 4 lay 3.3-fold (0.52 log units) below the measured number; measured number inside the range.
By their numbers in this assay, from the lowest: compound 1; then compound 4; then compound 2; then compound 3.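

In this assay, the ring on the amide-type nitrogen proves far more sensitive than the earlier halogen exchange suggested: 2-methylphenyl in place of 3-chloro-4-fluorophenyl gives a 50-fold higher number from compound 1 to compound 4 (1.70 log units; beyond the scatter), a large step, whereas chloro in place of fluoro, seen in compounds that carry phenyl rather than pyridin-4-yl on the chain carbon, gave only a 2.7-fold higher number from compound 2 to compound 3 (0.43 log units; beyond the scatter). Going by these compounds alone, this new step is still smaller than the exchange of pyridin-4-yl for phenyl on the chain carbon, a 1800-fold higher number from compound 1 to compound 3 (3.26 log units; beyond the scatter), so both regions of compound 1 affect the result, with the chain carbon showing the larger step so far. Nothing available here offers a measured explanation for the loss seen with compound 4.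

This single exchange removes chloro and fluoro and adds methyl all at once, so the compounds shown cannot separate the contribution of each change. Going by these compounds, it also remains open how the number would respond to 3-chlorophenyl, 4-fluorophenyl or 3-methylphenyl on the amide-type nitrogen, or to a saturated ring such as cyclohexyl there.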